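The source may report more compounds than this note shows. Statements on the series, on what has been measured and on what is new or still open speak of the compounds shown alone.

Among the compounds with values here, in an ADME assay on MT4 cells (Homo sapiens) for cytotoxicity, read by MTT assay, with a stated time of 4 days (on this read-out lower numbers stand for higher toxicity in this test and higher numbers for lower toxicity in this test), compound 2 `COc1ccccc1-c1cc(C)c(Nc2ccnc(Nc3ccc(C#N)cc3)n2)c(C)c1` gives 940 nM, the lowest of the three numbers so far. Compound 1 `Cc1cc(-c2ccc(F)cc2)cc(C)c1Nc1ccnc(Nc2ccc(C#N)cc2)n1` gives 4170 nM and compound 3 `Cc1cc(-c2cccc(F)c2)cc(C)c1Nc1ccnc(Nc2ccc(C#N)cc2)n1` gives 4120 nM; both sit apart from compound 2, as a 4.4-fold lower number from compound 1 to compound 2 (0.65 log units; beyond the scatter) and a 4.4-fold higher number from compound 2 to compound 3 (0.64 log units; beyond the scatter) show, whereas a 1.0-fold lower number from compound 1 to compound 3 (0.01 log units; within the scatter) leaves compounds 1 and 3 indistinguishable. Compound 4 `Cc1cc(-c2cccc(Cl)c2)cc(C)c1Nc1ccnc(Nc2ccc(C#N)cc2)n1` is not yet measured; it carries 3-chlorophenyl in place of 2-methoxyphenyl on an aromatic carbon. The step that bears on it most directly is the exchange of the 2-methoxyphenyl for a 3-fluorophenyl, a 4.4-fold higher number from compound 2 to compound 3 (0.64 log units; beyond the scatter), since a 3-chlorophenyl resembles the 3-fluorophenyl more than the 2-methoxyphenyl; the comparison of the two fluorophenyl analogues, a 1.0-fold lower number from compound 1 to compound 3 (0.01 log units; within the scatter), adds that those two were indistinguishable. Within the data shown here, no chlorophenyl analogue has been measured, so the size rests on the fluorophenyl compounds alone. A step of about a 3.7-fold higher number from compound 2 to compound 4 (0.57 log units; beyond the scatter) in this assay is therefore expected. Compound 4 is estimated at 3500 nM in this assay, within a range from 1500 nM to 8000 nM.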

Compound 4, half-maximal cytotoxic concentration: 2160 nM
Compound 4: middle estimate off by 1.6-fold (0.21 log units), on the high side; low and high end bracket the measured number.
By their numbers in this assay, from the lowest: compound 2; then compounds 4, 3 and 1 (each within the scatter of the next).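

In this assay the new step of a 2.3-fold higher number from compound 2 to compound 4 (0.36 log units; beyond the scatter) shows that the separation of compound 2 holds against a chlorinated ring as well as the fluorinated ones. Exchange of fluoro for chloro gives a 1.9-fold lower number from compound 3 to compound 4 (0.28 log units; within the scatter) and the 3-chlorophenyl against the 4-fluorophenyl gives a 1.9-fold lower number from compound 1 to compound 4 (0.29 log units; within the scatter) so compounds 1, 3 and 4 cannot be told apart here, and among the compounds shown only the 2-methoxyphenyl stands apart. Nothing at hand gives a reason for that separation.

The compounds shown do not separate the methoxy group from its place on the ring, which a 3-methoxyphenyl or a 2-chlorophenyl would address. On these data alone, it also stays open how this read-out responds to an aminophenyl or a carboxyphenyl at this position.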